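A few compounds are considered here, and "the series" means these few. Any claim that something is new, unique, unknown or untested is made for them only; others in the source may bear on it.

Compound 1, `COc1ccc(/C=C/c2cc(OC)cc(OC)c2/C=C/C(=O)c2cccc(Br)c2)cc1`, gives 5.1 ug/mL in a functional assay on B16-F10 cells (Mus musculus) for antiproliferative activity, read by MTT assay, with a stated time of 48 h; a lower number here means a stronger inhibitor, a higher number a weaker inhibitor.
Compound 2, `COc1ccc(/C=C/c2cc(OC)cc(OC)c2/C=C/C(=O)c2ccc(Br)cc2)cc1`, gives 6.5 ug/mL in this assay.
Compound 3, `CCOc1ccc(C(=O)/C=C/c2c(/C=C/c3ccc(OC)cc3)cc(OC)cc2OC)cc1`, gives 6.4 ug/mL in this assay.

Among these three numbers compound 2 carries the highest one, yet its nearest neighbour is compound 3, separated by a 1.0-fold lower number from compound 2 to compound 3 (0.01 log units; within the scatter), and the furthest is compound 1, separated by a 1.3-fold higher number from compound 1 to compound 2 (0.11 log units; within the scatter); both gaps sit within the scatter, so compound 2 cannot be called weaker than either.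

The next compound, compound 4, `COc1ccc(/C=C/c2cc(OC)cc(OC)c2/C=C/C(=O)c2ccc(-c3ccccc3)cc2)cc1`, differs from compound 2 in one place: phenyl in place of bromo on an aromatic carbon.

Every measured step touches the same aryl group on the carbonyl carbon. From compound 1 to compound 2 the bromo moves and the number shifts by a 1.3-fold higher number from compound 1 to compound 2 (0.11 log units; within the scatter); from compound 1 to compound 3 the change is a 1.3-fold higher number from compound 1 to compound 3 (0.10 log units; within the scatter); from compound 2 to compound 3 it is a 1.0-fold lower number from compound 2 to compound 3 (0.01 log units; within the scatter). None of these leaves the scatter, so exchanging one substituent for another at this position has so far left the read-out untouched. Phenyl in place of bromo is a larger change than any of these, but there is no step here that tells of it.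

Compound 4 is therefore expected to stay close to compound 2, the expected step being no change at the digits printed from compound 2 to compound 4 (within the scatter). The estimated value of compound 4 in this assay is 6.5 ug/mL, with a range from 3 ug/mL to 14 ug/mL.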

Compound 4, half-maximal inhibitory concentration: 10.6 ug/mL
Compound 4: the middle estimate sits 1.6-fold (0.21 log units) below what was measured, within the range that was stated.
By their numbers in this assay, from the lowest: compounds 1, 3, 2 and 4 (each within the scatter of the next, the first and the last beyond it).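

With a phenyl in place of bromo, six heavy atoms and a whole aromatic ring enter where one bromine stood, and in this assay the result is still only a 1.6-fold higher number from compound 2 to compound 4 (0.21 log units; within the scatter); the same holds for phenyl in place of ethoxy, a 1.7-fold higher number from compound 3 to compound 4 (0.22 log units; within the scatter). For the compounds shown here, the position therefore accepts a much larger group than the earlier compounds had tested, without a step from either of these neighbours that leaves the scatter, although the series now has its first step beyond the scatter, a modest one: a 2.1-fold higher number from compound 1 to compound 4 (0.32 log units; beyond the scatter), where the 4-phenylphenyl group replaces the 3-bromophenyl group as a whole. No measurement bears on this result, and nothing here accounts for that step.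

Going by these compounds alone, all the groups at this position so far are bromo, ethoxy and phenyl, none carrying a charge or a hydrogen-bond donor, so it remains open whether an amine or a carboxylic acid would stay within the scatter as they do. The compounds shown also vary only the aryl group on the carbonyl carbon, which leaves open how the read-out responds to any change elsewhere on the shared core, such as a longer chain in place of a methoxy group.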